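Three limits on a shared core, a pyridine amide next

The compounds below may be only part of what the source reports. "The series", "measured", "known", "first", "only" and "open" are said of these compounds alone.

Compound 1 `C=CC(=O)Nc1cccc(-c2nc3ccccc3s2)c1`: > 25000 nM
Compound 2 `O=C(O)/C=C/C(=O)Nc1cccc(-c2nc3ccccc3s2)c1`: > 25000 nM
Compound 3 `CC(C)(CCl)C(=O)Nc1cccc(-c2nc3ccccc3s2)c1`: > 25000 nM

In an ADME assay on HepG2 cells (Homo sapiens) for inhibition, with a stated time of 72 h (a higher number here means that more compound is needed for the effect, a lower number that less compound is needed), compound 2 gives > 25000 nM, which is a limit of the assay and not a number. The other two values are limits as well, so compound 2 stands only at a limit among them. The steps a step that the two limits leave unreadable from compound 1 to compound 2, a step that the two limits leave unreadable from compound 1 to compound 3 and a step that the two limits leave unreadable from compound 2 to compound 3 are all of unreadable size. Compound 4 `O=C(Nc1cccc(-c2nc3ccccc3s2)c1)c1cccnc1Cl` differs from compound 2 by 2-chloropyridin-3-yl in place of 2-carboxyethenyl on a carbonyl carbon. Among the measured compounds shown here, no measured step reads on this change, since every value sits at the limit of > 25000 nM in this assay, at which 3 of the 3 values shown sit. The expected step is a number no higher from compound 2 to compound 4 (the limit leaves the size open). For compound 4 in this assay the estimate is 25000 nM, with a range from 6000 nM to 100000 nM, most likely again reported as a limit.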

Compound 4, half-maximal effective concentration: > 25000 nM
Compound 4: a limit, no number; the forecaster's own chance of this, stated with the estimate: 70%; the middle value lies on the limit itself.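

Compound 4 gives > 25000 nM in this assay, a limit of the assay and not a number. Its steps to compound 1, compound 2 and compound 3 cannot be read: the limit of > 25000 nM in this assay, at which 4 of the 4 values shown sit.

The compounds shown leave open whether any group on the carbonyl carbon of the shared core changes the value in this assay.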